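Swapping a bromo methyl ester for a chloro ethyl ester

The source may report more compounds than this note shows. Statements on the series, on what has been measured and on what is new or still open speak of the compounds shown alone.

In a physicochemical assay for metabolic stability, read by LC-MS, in phosphate buffer, with a stated time of 120 min, at pH 7.4, tested at 1 uM (on this read-out lower numbers stand for a less stable compound and higher numbers for a more stable compound), compound 1 `CC#CCn1c(N2CCC[C@@H](N)C2)nc2c1c(=O)n(Cc1ccc(Br)cc1C(=O)OC)c(=O)n2C` gives 99.4% and sits level with compound 3 `CC#CCn1c(N2CCC[C@@H](N)C2)nc2c1c(=O)n(Cc1ccc(Br)cc1C(=O)O)c(=O)n2C` at 99.2% on this scale, while compound 2 `CC#CCn1c(N2CCC[C@@H](N)C2)nc2c1c(=O)n(Cc1ccc(Cl)cc1C(=O)OCc1oc(=O)oc1C)c(=O)n2C` lies far lower at 12% on the same scale. Compound 4 `CC#CCn1c(N2CCC[C@@H](N)C2)nc2c1c(=O)n(Cc1ccc(Cl)cc1C(=O)OCC)c(=O)n2C` differs from compound 1 in one place (4-chloro-2-(ethoxycarbonyl)phenyl in place of 4-bromo-2-(methoxycarbonyl)phenyl on a saturated chain carbon bound to an aromatic nitrogen), with 4-chloro-2-(ethoxycarbonyl)phenyl in place of 4-bromo-2-(methoxycarbonyl)phenyl on a saturated chain carbon bound to an aromatic nitrogen. Within the data shown here, the only measured step, hydrogen in place of methyl on an oxygen next to a carbonyl group, runs a number 0.2 percentage points lower from compound 1 to compound 3 (within the scatter) and stays within the scatter. Among the measured compounds shown here, no measured step isolates chlorine for bromine or ethyl for methyl. The expected change is small, an estimated a number 2.4 percentage points lower from compound 1 to compound 4 (within the scatter) within the scatter. Compound 4 is expected to give 97% in a range of 88% to 100% when measured.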

Compound 4, percent of the compound remaining: 99.5%
Compound 4: the middle estimate sits 2.5 percentage points below what was measured, within the range that was stated.
By their numbers in this assay, from the lowest: compound 2; then compounds 3, 1 and 4 (each within the scatter of the next).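

In this assay, 4-chloro-2-(ethoxycarbonyl)phenyl in place of 4-bromo-2-(methoxycarbonyl)phenyl gives a number 0.1 percentage points higher from compound 1 to compound 4 (within the scatter), so this position tolerates the change with no visible loss. Against the free acid, the same group in place of 4-bromo-2-carboxyphenyl gives a number 0.3 percentage points higher from compound 3 to compound 4 (within the scatter), again no separable difference. With chlorine held constant, one carbon atom in place of the ring-bearing group of 7 heavy atoms gives a number 87.5 percentage points higher from compound 2 to compound 4 (beyond the scatter), so among these compounds the low value goes with that group, not with chlorine.

Chlorine and ethyl entered together, so neither can be read alone, and how an amide or a longer chain would behave here stays open. No supporting measurement explains these stability values.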